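The compounds below may be only part of what the source reports. "The series", "measured", "known", "first", "only" and "open" are said of these compounds alone.

Measured so far:
- compound 1, `Cc1ccnc(-c2cnc(C(=O)CCCCCCc3ccccc3)o2)c1`, 0.6 nM
- compound 2, `O=C(CCCCCCc1ccccc1)c1ncc(-c2cncnc2)o1`, 22 nM
- compound 3, `O=C(CCCCCCc1ccccc1)c1ncc(-c2nnn[nH]2)o1`, 63 nM

These values come from an assay (Rattus norvegicus) for inhibition of Fatty-acid amide hydrolase 1 (Homo sapiens); a higher number here means a weaker inhibitor, a lower number a stronger inhibitor. Compound 3 stands highest of the three numbers; the nearest is compound 2, as shown by a 2.9-fold higher number from compound 2 to compound 3 (0.46 log units; beyond the scatter), and the furthest is compound 1, as shown by a 110-fold higher number from compound 1 to compound 3 (2.02 log units; beyond the scatter).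

Compound 4, `O=C(CCCCCCc1ccccc1)c1ncc(C(=O)C(F)(F)F)o1`, is reached from compound 3 by the change ((trifluoromethyl)carbonyl in place of 1H-tetrazol-5-yl on an aromatic carbon). Going by the values given here, no measured step exchanges the same groups, so only indirect guidance exists: a 37-fold higher number from compound 1 to compound 2 (1.56 log units; beyond the scatter) and a 110-fold higher number from compound 1 to compound 3 (2.02 log units; beyond the scatter) show that replacing the 4-methylpyridin-2-yl moves this assay a great deal, while a 2.9-fold higher number from compound 2 to compound 3 (0.46 log units; beyond the scatter) is modest. For compound 4 the expected step is a 3.2-fold lower number from compound 3 to compound 4 (0.50 log units; beyond the scatter). The estimate for compound 4 is 20 nM, expected between 3 nM and 150 nM.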

Compound 4, inhibition constant: 4 nM
Estimate against measurement, compound 4: 5.0-fold (0.70 log units) above; the range from low to high includes it.
By their numbers in this assay, from the lowest: compound 1; then compound 4; then compound 2; then compound 3.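

At this carbon next to the ring oxygen, an aromatic ring is not needed for a low number in this assay: the ringless (trifluoromethyl)carbonyl gives a 16-fold lower number from compound 3 to compound 4 (1.20 log units; beyond the scatter) and a 5.5-fold lower number from compound 2 to compound 4 (0.74 log units; beyond the scatter), both beyond the usual scatter. It still falls short of the 4-methylpyridin-2-yl, with a 6.7-fold higher number from compound 1 to compound 4 (0.82 log units; beyond the scatter) for this swap. No measurement here accounts for these steps.

Open is whether the trifluoromethyl part matters, since a plain acetyl group is not among these compounds. A carboxylic acid or a nitrile at this carbon also remains untested among those shown.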